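A few compounds are considered here, and "the series" means these few. Any claim that something is new, unique, unknown or untested is made for them only; others in the source may bear on it.

Compound 1, `Cc1ccccc1-c1c(C(=O)N(C)Cc2cc(C(F)(F)F)cc(C(F)(F)F)c2)n(C)c(=O)c2ccccc12`, in an assay on IM-9 cells for binding affinity to Substance-P receptor (Homo sapiens) (a lower number here means a stronger inhibitor, a higher number a weaker inhibitor), gives 1.3 nM.
Compound 2, `CN(Cc1cc(C(F)(F)F)cc(C(F)(F)F)c1)C(=O)c1c(-c2ccccc2)c2ccccc2c(=O)n1C`, in this assay gives 1.2 nM.

Among the measured compounds shown here, compound 2 holds the lower of these two numbers, but its only neighbour, compound 1, sits within the scatter of it, so the two cannot be ranked. Compound 3, `CN(Cc1cc(C(F)(F)F)cc(C(F)(F)F)c1)C(=O)c1c(-c2ccccc2)c2cc(Cl)ccc2c(=O)n1C`, has not yet been measured. It differs from compound 2 by chloro in place of hydrogen on an aromatic carbon, on a six-membered aromatic ring of carbon only that is part of a fused system of two rings. For the measured compounds named here, the single measured step, a 1.1-fold lower number from compound 1 to compound 2 (0.03 log units; within the scatter), also swaps a small aromatic substituent for hydrogen, though on another ring, and it barely moved the number. On that basis the change to compound 3 is expected to be small as well, with no clear direction: a 1.3-fold higher number from compound 2 to compound 3 (0.10 log units; within the scatter). Compound 3 is therefore estimated at 1.5 nM, likely between 0.5 nM and 5 nM.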

Compound 3, half-maximal inhibitory concentration: 3.4 nM
Compound 3: middle estimate off by 2.3-fold (0.36 log units), on the low side; the measured number falls inside the stated range.
By their numbers in this assay, from the lowest: compounds 2 and 1 (each within the scatter of the next); then compound 3.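

In this assay, chloro in place of hydrogen on an aromatic carbon of the fused system gives a 2.8-fold higher number from compound 2 to compound 3 (0.45 log units; beyond the scatter), a modest step but one beyond the scatter. Among the compounds shown here, the only earlier step, a 1.1-fold lower number from compound 1 to compound 2 (0.03 log units; within the scatter), lay within the scatter and involved another ring, so this is the first sign in these compounds that a single added atom can shift the number, and here it shifts it towards a weaker inhibitor. No measurement shown here explains this rise.

Going by these compounds, with one substituent at one carbon, it remains open whether the rise belongs to chloro itself or to any group at this position, which fluoro, methoxy or an amine there could help to separate. On these data alone, whether the other carbons of this ring respond in the same way also remains open.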